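Ethyl Added to the Anilino Ring of a Shared Core

This account rests on a few compounds, and the source may have more. Where it says the series, first, only, none or still open, it means among the compounds named here.

Of the compounds shown here, three sharing one core have been tested in a functional assay on PC-3 cells (Homo sapiens) for inhibition, read by MTT assay, with a stated time of 72 h; a higher number here means a weaker inhibitor, a lower number a stronger inhibitor. Compound 1 `O=C(CSc1nc(Nc2ccccc2)c2ccccc2n1)Nc1ccccc1F` gives 12400 nM. Compound 2 `O=C(CSc1nc(Nc2ccccc2)c2ccccc2n1)Nc1cccc(Br)c1` gives 11400 nM, and compound 3 `C=CC(=O)Nc1cccc(NC(=O)CSc2nc(Nc3ccccc3)c3ccccc3n2)c1` gives 8740 nM. The three differ only in the group on the amide-type nitrogen: the step of a 1.1-fold lower number from compound 1 to compound 2 (0.04 log units; within the scatter) puts 3-bromophenyl in place of 2-fluorophenyl, the step of a 1.4-fold lower number from compound 1 to compound 3 (0.15 log units; within the scatter) brings in 3-((vinylcarbonyl)amino)phenyl, and the step of a 1.3-fold lower number from compound 2 to compound 3 (0.12 log units; within the scatter) puts (vinylcarbonyl)amino in place of bromo on an aromatic carbon. Within the data shown here, compound 3 has the lowest of the three numbers, yet its gaps to compound 2 and to compound 1 both lie within the scatter, so no compound can be called the strongest.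

Compound 4 `C=CC(=O)Nc1cccc(NC(=O)CSc2nc(Nc3ccc(CC)cc3)c3ccccc3n2)c1` has not been measured. It differs from compound 3 in one place: ethyl in place of hydrogen on an aromatic carbon. The change sits on the anilino ring, a part left untouched in all three measured steps, so none of them bears on it directly. What those steps do show is that changing the group on the amide-type nitrogen moved this assay little. Compound 4 is therefore expected to show a step of a 1.2-fold lower number from compound 3 to compound 4 (0.07 log units; within the scatter), with nothing beyond the scatter. The estimate for compound 4 in this assay is 7500 nM, expected to fall between 3000 nM and 20000 nM.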

Compound 4, half-maximal inhibitory concentration: 24300 nM
Compound 4: the middle estimate sits 3.2-fold (0.51 log units) below what was measured; measured number above the stated range.
By their numbers in this assay, from the lowest: compounds 3, 2, 1 and 4 (each within the scatter of the next, the first and the last beyond it).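

In this assay, among these compounds, ethyl on the anilino ring, on a carbon para to a large group, gives a 2.8-fold higher number from compound 3 to compound 4 (0.44 log units; beyond the scatter), a modest weakening and the only step in this set that lies beyond the scatter. The anilino ring therefore does respond to change, even though the three earlier swaps on the amide-type nitrogen all stayed within the scatter, and here adding just two carbons in place of a hydrogen was enough to raise the number. Nothing available explains why this position responds in this way.

As far as these compounds go, a single ethyl at a single position cannot show whether the effect belongs to ethyl alone, so it remains open whether methyl, a longer chain such as propyl, or a different kind of group such as an amine or a carboxylic acid on the same carbon would raise the number, leave it unchanged or lower it. From the compounds shown here alone, it is also open whether ethyl would have the same effect on the anilino ring of compound 1 or compound 2, which carry other groups on the amide-type nitrogen.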